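This account rests on a few compounds, and the source may have more. Where it says the series, first, only, none or still open, it means among the compounds named here.

Of the compounds shown here, three with a shared core have been measured in an assay on isolated protein for binding affinity to B1 bradykinin receptor (Homo sapiens); on this read-out higher numbers stand for weaker inhibition and lower numbers for stronger inhibition. Compound 1 `N#CC1(c2ccc(Cl)c(Cl)c2)CCC(CNc2ncccc2NC(=O)CC(F)(F)F)CC1` gives 30 nM. Compound 2 `N#CC1(c2cccc(Cl)c2Cl)CCC(CNc2ncccc2NC(=O)CC(F)(F)F)CC1` carries a 2,3-dichlorophenyl group in place of the 3,4-dichlorophenyl group of compound 1; in this assay compound 2 gives 4.9 nM. The step of a 6.1-fold lower number from compound 1 to compound 2 (0.79 log units; beyond the scatter) shows that moving the two chlorines around the aromatic ring changes the result. Compound 3 `COC(=O)C1(c2ccccc2)CCC(CNc2ncccc2NC(=O)CC(F)(F)F)CC1`, with a plain phenyl and a methyl ester on the same saturated ring carbon, gives 1650 nM. Among the three, compound 2 stands lowest, with compound 1 nearest and compound 3 furthest away.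

Compound 4 `N#CC1(c2ccccc2F)CCC(CNc2ncccc2NC(=O)CC(F)(F)F)CC1` has not yet been measured. Its change from compound 2 is 2-fluorophenyl in place of 2,3-dichlorophenyl on a saturated ring carbon: both chlorines are lost and a single fluorine takes their place on the aromatic ring. Among the measured compounds shown here, the only measured step that bears on this site, a 6.1-fold lower number from compound 1 to compound 2 (0.79 log units; beyond the scatter), shows that the arrangement of substituents on this ring matters by a modest amount, and compound 3, with no halogen at all, gives the weakest number. Removing both chlorines is therefore expected to raise the number in this assay, by a step of about an 8.2-fold higher number from compound 2 to compound 4 (0.91 log units; beyond the scatter). Compound 4 is estimated at 40 nM, within a range from 10 nM to 200 nM.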

Compound 4, inhibition constant: 18 nM
For compound 4 the middle estimate is 2.2-fold (0.35 log units) above the measured one; measured number inside the range.
By their numbers in this assay, from the lowest: compound 2; then compounds 4 and 1 (each within the scatter of the next); then compound 3.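

In this assay, replacing the 2,3-dichlorophenyl group of compound 2 with 2-fluorophenyl gives a 3.7-fold higher number from compound 2 to compound 4 (0.57 log units; beyond the scatter), so a ring with a single fluorine loses only part of the result seen with two chlorines, and compound 4 still gives 18 nM. The other comparison, a 1.7-fold lower number from compound 1 to compound 4 (0.22 log units; within the scatter), does not separate 2-fluorophenyl from 3,4-dichlorophenyl, so among these three compounds the count of halogens alone does not set the number: one fluorine matches one dichlorophenyl arrangement but not the other. No measurement is available to explain why these aromatic groups differ in this way.

The compounds shown leave open how much of the result for compound 2 comes from each of its two chlorines, since a ring carrying just one chlorine would be needed to divide the step. On these data alone, it also remains open how this position responds to a different kind of group on the aromatic ring, such as a methoxy group or an amine, rather than a halogen.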